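The source may report more compounds than this note shows. Statements on the series, on what has been measured and on what is new or still open speak of the compounds shown alone.

Compounds measured so far:
compound 1, `CNS(=O)(=O)Cc1noc2ccc(F)cc12`: 35 mg/kg
compound 2, `CN1CCN(S(=O)(=O)Cc2noc3ccc(F)cc23)CC1`: 100 mg/kg
compound 3, `CNS(=O)(=O)Cc1noc2ccc(Br)cc12`: 15 mg/kg

In a functional assay on the whole organism (strain STD-dd) with Mus musculus as the target, in the maximal electroshock model, with a stated time of 2 h (a higher number here means that more compound is needed for the effect, a lower number that less compound is needed), compound 3 gives the lowest number of the three. For the measured compounds named here, compound 1 is its nearest neighbour, separated from it by the step of a 2.3-fold lower number from compound 1 to compound 3 (0.37 log units; beyond the scatter), and compound 2 stands furthest from it; no single-change step links compound 3 to compound 2, so only their two values, taken as they are, show how far apart they lie.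

The unmeasured compound 4 is `CN1CCN(S(=O)(=O)Cc2noc3ccc(Br)cc23)CC1`. It differs from compound 3 in one place: 4-methylpiperazin-1-yl in place of methylamino on a sulfonyl sulfur. The same exchange has been made once before, between compound 1 and compound 2, where it gave a 2.9-fold higher number from compound 1 to compound 2 (0.46 log units; beyond the scatter), a modest change that went beyond the scatter. Going by the values given here, that is the only measured step that bears on the present one, and nothing in the data suggests that the bromo-bearing core should answer the exchange differently from the fluoro-bearing core. A modest rise in the dose, beyond the scatter, is therefore what the step from compound 3 to compound 4 is expected to bring in this assay.

Compound 4 is thus estimated at 43 mg/kg, with a range from 20 mg/kg to 90 mg/kg. The expected step this estimate implies is a 2.9-fold higher number from compound 3 to compound 4 (0.46 log units; beyond the scatter).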

Compound 4, dose for half-maximal effect: 88 mg/kg
Beside the measured number, compound 4's estimate is 2.0-fold (0.31 log units) below it, within the range that was stated.
By their numbers in this assay, from the lowest: compound 3; then compound 1; then compounds 4 and 2 (each within the scatter of the next).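

In this assay, the exchange of methylamino for 4-methylpiperazin-1-yl on the sulfonyl sulfur now has a second reading on the bromo-bearing core, a 5.9-fold higher number from compound 3 to compound 4 (0.77 log units; beyond the scatter), and it runs in the same direction as on the fluoro-bearing core, with a gap that does not separate the two readings: the same change on two cores in this assay, a 2.9-fold higher number (0.46 log units; beyond the scatter) from compound 1 to compound 2 and a 5.9-fold higher number (0.77 log units; beyond the scatter) from compound 3 to compound 4, 2.1-fold (0.31 log units) apart, within the scatter of two such steps. The exchange of fluoro for bromo on the aromatic carbon, by contrast, now also has a reading with 4-methylpiperazin-1-yl on the sulfonyl sulfur, a 1.1-fold lower number from compound 2 to compound 4 (0.06 log units; within the scatter), which is smaller than the step seen with methylamino, although that gap cannot be taken as a real difference between the two settings: the same change on two cores in this assay, a 2.3-fold lower number (0.37 log units; beyond the scatter) from compound 1 to compound 3 and a 1.1-fold lower number (0.06 log units; within the scatter) from compound 2 to compound 4, 2.1-fold (0.31 log units) apart, within the scatter of two such steps. On both cores, then, the methylamino compound carries the lower number of its pair, compound 1 against compound 2 and compound 3 against compound 4.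

The compounds shown leave open how an unsubstituted amino group, a dimethylamino group or a morpholin-4-yl group on the sulfonyl sulfur would stand, so the rise cannot yet be tied to the ring or to the loss of the hydrogen-bond donor. They also leave open how chloro or a plain hydrogen on the aromatic carbon would compare with fluoro and bromo.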